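From 3-fluorophenyl to oxan-4-yl on the carbonyl

The source may report more compounds than this note shows. Statements on the series, on what has been measured and on what is new or still open speak of the compounds shown alone.

In a functional assay on A2780 cells (Homo sapiens) for antiproliferative activity, read by CellTiter-Glo, with a stated time of 72 h (a lower number here means a stronger inhibitor, a higher number a weaker inhibitor), compound 1 `C[C@@H](c1ccc(NC(=O)N2CC(c3ccc(N)nc3)C2)cc1)N1Cc2ccccc2C1=O` gives 5.9 nM and compound 2 `C[C@H](NC(=O)c1cccc(F)c1)c1ccc(NC(=O)N2CC(c3ccc(N)nc3)C2)cc1` gives 7.6 nM. Compound 2 therefore stands level with compound 1 within the scatter, and no other measured value places it.

Compound 3 `C[C@H](NC(=O)C1CCOCC1)c1ccc(NC(=O)N2CC(c3ccc(N)nc3)C2)cc1` has oxan-4-yl in place of 3-fluorophenyl on a carbonyl carbon.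

Going by the values given here, the only measured step is a 1.3-fold higher number from compound 1 to compound 2 (0.11 log units; within the scatter). It changes a larger unit on a saturated chain carbon and does not isolate this group, so it bears on the change only indirectly. Among the compounds with values here, no measured compound carries oxan-4-yl. With that single small step as a guide, no shift beyond the scatter is expected in this assay, with a slight lean towards a higher number.

The estimated step is a 1.4-fold higher number from compound 2 to compound 3 (0.16 log units; within the scatter). For compound 3 the estimated value is 11 nM, with an expected range of 3.5 nM to 35 nM.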

Compound 3, half-maximal inhibitory concentration: 46 nM
Compound 3: middle estimate off by 4.2-fold (0.62 log units), on the low side; measured number above the stated range.
By their numbers in this assay, from the lowest: compounds 1 and 2 (each within the scatter of the next); then compound 3.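

In this assay, going by these compounds alone, this carbonyl position proves sensitive to the group it carries: oxan-4-yl in place of 3-fluorophenyl gives a 6.1-fold higher number from compound 2 to compound 3 (0.78 log units; beyond the scatter), the first step in this set to lie beyond the scatter. The wider replacement gives a 7.8-fold higher number from compound 1 to compound 3 (0.89 log units; beyond the scatter), so among these three compounds, the two whose changing unit holds a six-membered aromatic ring of carbon only stay level with each other, and compound 3, without that ring, has the higher number. No measured evidence bears on why the number rises.

Going by these compounds, it remains open whether the step follows the loss of the aromatic ring or the entry of the ring oxygen; a cyclohexyl group on the same carbonyl carbon would separate the two. On these data alone, the part played by the fluorine is also open, and an unsubstituted phenyl group would address it.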